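The compounds below may be only part of what the source reports. "The series", "measured", "known", "first", "only" and "open" are said of these compounds alone.

In an ADME assay on HepG2 2.2.15 cells (Homo sapiens) for cytotoxicity (on this read-out higher numbers stand for lower toxicity in this test and lower numbers for higher toxicity in this test), compound 1 `O=C(CCCCC(=O)Nc1ncc(Cc2ccc(F)cc2)s1)Nc1ncc(Cc2ccc(F)cc2)s1` returns only a limit, > 50000 nM, which is a limit of the assay and not a number. Compound 2 `Cc1cc(C(C)C)ccc1OC(c1ccc(Cl)cc1)c1cnc(NC(=O)OC(C)(C)C)s1` likewise returns a limit in this assay, > 50000 nM. Compound 3 `O=C(Nc1ncc(C(Oc2ccc3cc(Br)ccc3c2)c2ccc(Cl)cc2)s1)c1cccs1` has no single number in this assay; its result is recorded only as "not toxic" (no number reported). Compound 3 therefore stands alongside the other two, with no measured toxicity in this assay and no value that would set it apart from the limit of > 50000 nM in this assay, at which 2 of the 3 values shown sit.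

Compound 4 `Clc1ccc(C(Oc2ccc3cc(Br)ccc3c2)c2cnc(NCC3CCOCC3)s2)cc1` differs from compound 3 in one place: (oxan-4-yl)methyl in place of (thiophen-2-yl)carbonyl on a nitrogen on an aromatic ring. For the measured compounds named here, no step between measured compounds is available, so the size of this change in this assay cannot be taken from any comparison. Since every measured result in this assay shows no toxicity, the expectation for compound 4 is no step beyond the scatter, with the outcome most likely again a limit rather than a number. Compound 4 is estimated at 50000 nM in this assay, with an expected range from 20000 nM to 100000 nM.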

Compound 4, half-maximal cytotoxic concentration: "not toxic" (no number reported)
For compound 4 the study gives words and no number; no gap can be computed for the estimate.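

Compound 3 and compound 4 are both recorded only as "not toxic" in this assay, so no new step can be read from this pair. The compounds shown leave open whether (oxan-4-yl)methyl in place of (thiophen-2-yl)carbonyl shifts the half-maximal cytotoxic concentration at all; the only reference is: the limit of > 50000 nM in this assay, at which 2 of the 4 values shown sit.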